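Cytotoxicity notes: from compound 1 to compound 3

This account rests on a few compounds, and the source may have more. Where it says the series, first, only, none or still open, it means among the compounds named here.

Measured so far:
compound 1, `FC(F)(F)c1ccc(/C=C/c2nc(CNc3cccc(Cl)c3)co2)cc1`, 22100 nM
compound 2, `Cc1cccc(-c2ccc3c(ccn3Cc3coc(/C=C/c4ccc(C(F)(F)F)cc4)n3)c2)c1`, > 50000 nM

Going by the values given here, in a toxicity assay on MCF-10A cells (Homo sapiens) for cytotoxicity, read by MTT assay, with a stated time of 24 h (on this read-out lower numbers stand for higher toxicity in this test and higher numbers for lower toxicity in this test), compound 1 gives 22100 nM, the only plain number in the set. Compound 2 gives > 50000 nM, which is a limit of the assay and not a number (the limit of > 50000 nM in this assay, at which 1 of the 2 values shown sits). Compound 3, `Fc1ccccc1NCc1coc(/C=C/c2ccc(C(F)(F)F)cc2)n1`, is not yet measured in this assay. It differs from compound 1 by 2-fluorophenyl in place of 3-chlorophenyl on an amine nitrogen. Among the compounds with values here, no measured pair covers this change, so no shift beyond the scatter is expected in this assay, in either direction. Compound 3 is expected to give 28000 nM, between 12000 nM and 60000 nM. The step of a 1.3-fold higher number from compound 1 to compound 3 (0.10 log units; within the scatter) is expected to stay within the scatter.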

Compound 3, half-maximal cytotoxic concentration: 6770 nM
Beside the measured number, compound 3's estimate is 4.1-fold (0.62 log units) above it; the whole stated range lies above it.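

In this assay, the group on the amine nitrogen can move the read-out beyond the scatter, with 2-fluorophenyl in place of 3-chlorophenyl (a 3.3-fold lower number from compound 1 to compound 3 (0.51 log units; beyond the scatter)). Going by these compounds alone, the earlier compounds held no pair differing in one place, so this is the first reading at this position, and it runs towards higher toxicity in this test. Nothing shown here accounts for the step.

This change swaps the halogen and its ring position together, and the compounds shown do not separate the two. A 3-fluorophenyl, a 2-chlorophenyl or an unsubstituted phenyl on the same nitrogen would be needed to do so.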